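Pyridin-2-yl Replacing Benzyl on the Amide Nitrogen

The source may report more compounds than this note shows. Statements on the series, on what has been measured and on what is new or still open speak of the compounds shown alone.

Compound 1 `CCc1nnc(NC(=O)Cn2c(-c3ccccc3)cc(-c3ccccc3)c2-c2ccco2)s1`: < 50000 nM in an ADME assay on HEK-293T cells (Homo sapiens) for cytotoxicity, read by MTT assay, with a stated time of 72 h; on this read-out higher numbers stand for weaker inhibition and lower numbers for stronger inhibition
Compound 2 `O=C(Cn1c(-c2ccccc2)cc(-c2ccccc2)c1-c1ccco1)NCc1ccccc1`: < 50000 nM in this assay

The value of compound 1 is a limit of the assay, not a number. The value of compound 2 is likewise only a limit, so compound 2 stands at a limit in this assay. The step that the two limits leave unreadable from compound 1 to compound 2 cannot be read, as the limit of < 50000 nM in this assay, at which 2 of the 2 values shown sit, shows.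

Compound 3 `O=C(Cn1c(-c2ccccc2)cc(-c2ccccc2)c1-c1ccco1)Nc1ccccn1` differs from compound 2 by pyridin-2-yl in place of benzyl on an amide-type nitrogen. Among the measured compounds shown here, no measured step bears on this change, and nothing in the data suggests a shift beyond the scatter. The estimated step is a step that the limit leaves unreadable from compound 2 to compound 3. Compound 3 is expected at 30000 nM, with a range from 10000 nM to 50000 nM.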

Compound 3, half-maximal inhibitory concentration: < 50000 nM
Compound 3: a limit, no number; the forecaster's own chance of this, stated with the estimate: 70%; the middle value is on the limit's open side.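

Among the compounds shown here, compound 3 gives a limit, not a number, just as compound 1 and compound 2 do, so no step among them can be read. In this assay the compounds shown leave open where each true value lies and whether the group on the amide-type nitrogen matters at all.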